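This account rests on a few compounds, and the source may have more. Where it says the series, first, only, none or still open, it means among the compounds named here.

Working notes on the series. Compound 1 `CCC1(Cc2ccccc2)OS(=O)(=O)C=C1OCc1ccc(F)cc1` has been run in an ADME assay on HEL cells (Homo sapiens) for cytotoxicity, with a stated time of 3 days; a higher number here means that more compound is tolerated, a lower number that less compound is tolerated. In this assay compound 1 gives > 50000 nM, and this figure is a limit of the assay rather than a measured number (the limit of > 50000 nM in this assay, at which 1 of the 2 values shown sits). Compound 2 `CCC1(Cc2ccccc2)OS(=O)(=O)CC1=O` in this assay gives 200000 nM. Among the compounds with values here, no pair of measured compounds differs in a single place, so compound 1 stands on its limit alone, without a measured step to set it against.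

Compound 3 `CCC1(Cc2ccccc2)OS(=O)(=O)C=C1OCc1ccccc1Cl` is still to be measured in this assay. It differs from compound 1 by 2-chlorophenyl in place of 4-fluorophenyl on a saturated chain carbon bound to an oxygen on an unsaturated carbon. In this assay no shift beyond the usual scatter is expected in either direction from this change. The expected step is a step that the limit leaves unreadable from compound 1 to compound 3. Compound 3 is therefore estimated at 100000 nM, with a range from 30000 nM to 300000 nM, and it is likely that this assay again reports only a limit.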

Compound 3, half-maximal cytotoxic concentration: 38000 nM
For compound 3 the middle estimate is 2.6-fold (0.42 log units) above the measured one; measured number inside the range.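

In this assay, 2-chlorophenyl in place of 4-fluorophenyl on a saturated chain carbon bound to an oxygen on an unsaturated carbon gives an at least 1.3-fold lower number from compound 1 to compound 3 (0.11 log units; that floor lies within the scatter). Compound 1 gives > 50000 nM, which is a limit of the assay, so the step is known only as a floor and its full size cannot be read. Compound 3 is the first substituted benzyl compound in the series to give a number rather than a limit, which leaves compound 1 as the only value shown at that limit: the limit of > 50000 nM in this assay, at which 1 of the 3 values shown sits.

The compounds shown leave open whether the halogen or its place on the ring matters more, a question that 4-chlorophenyl at the same place would separate. Also open, from the compounds shown here alone, is how this assay responds to a group of another kind there, such as an amine.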